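The source may report more compounds than this note shows. Statements on the series, on what has been measured and on what is new or still open speak of the compounds shown alone.

Measured compounds:
compound 1 `Cc1ncc(-c2nc(C(F)(F)F)sc2N2CCN(C(=O)Cn3cnc4cccnc43)[C@H](C)C2)cn1`, 168 nM
compound 2 `COc1ncc(-c2nc(C(F)(F)F)sc2N2CCN(C(=O)Cn3nc(C)nc3C)[C@H](C)C2)cn1`, 558 nM
compound 3 `Cc1nc(C)n(CC(=O)N2CCN(c3sc(C(F)(F)F)nc3-c3cnc(OC4CCC4)nc3)C[C@H]2C)n1`, 78 nM

In a functional assay on U2OS cells for antagonist activity at C-X-C chemokine receptor type 3 (Homo sapiens), read by beta-arrestin recruitment (on this read-out lower numbers stand for stronger inhibition and higher numbers for weaker inhibition), compound 3 gives the lowest of the three numbers, with compound 1 nearest and compound 2 furthest away. Compound 4 `Cc1ncc(-c2nc(C(F)(F)F)sc2N2CCN(C(=O)Cn3nc(C)nc3C)[C@H](C)C2)cn1` is not yet measured; it differs from compound 3 by methyl in place of cyclobutyloxy on an aromatic carbon. Among the measured compounds shown here, the only measured step at this position is a 7.2-fold lower number from compound 2 to compound 3 (0.85 log units; beyond the scatter), where the larger cyclobutyloxy gave the lower number; compound 1, which carries the same methyl but a different amide head, shows 168 nM. Removing the cyclobutyloxy is therefore expected to raise the number, a step of a 4.5-fold higher number from compound 3 to compound 4 (0.65 log units; beyond the scatter). Compound 4 is estimated at 350 nM, in the range 120 nM to 1000 nM.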

Compound 4, half-maximal inhibitory concentration: 578 nM
The estimate for compound 4 lay 1.7-fold (0.22 log units) below the measured number; measured number inside the range.
By their numbers in this assay, from the lowest: compound 3; then compound 1; then compounds 2 and 4 (each within the scatter of the next).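

In this assay, methyl and methoxy on the same core cannot be told apart (a 1.0-fold higher number from compound 2 to compound 4 (0.02 log units; within the scatter)), so among the three groups at this aromatic carbon only cyclobutyloxy gives a distinct number (a 7.4-fold higher number from compound 3 to compound 4 (0.87 log units; beyond the scatter)). With methyl held fixed, the amide head also matters (a 3.4-fold higher number from compound 1 to compound 4 (0.54 log units; beyond the scatter)). No measured evidence accounts for either step.

Still open, as far as these compounds go, is whether the gain needs the oxygen or only the four-membered ring, which cyclobutyl or cyclobutylamino here would separate. Also open, from the compounds shown here alone, is whether the amide head of compound 1 adds to cyclobutyloxy.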